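The source may report more compounds than this note shows. Statements on the series, on what has been measured and on what is new or still open speak of the compounds shown alone.

Measured to date:
compound 1 `COC(=O)C1=C(C)N=C(C)/C(=C(\O)OC)C1c1ccccc1Cl`: 2.19 nM
compound 2 `COC(=O)C1=C(C)N=C(C)/C(=C(\O)OC)C1c1cc(OC)c(OC)cc1OC`: 1000000 nM
compound 3 `COC(=O)C1=C(C)N=C(C)/C(=C(\O)OC)C1c1cc([N+](=O)[O-])ccc1Cl`: 30.2 nM

In a functional assay (muscle tissue) with Cavia porcellus as the target (on this read-out lower numbers stand for an effect already at smaller amounts and higher numbers for an effect only at larger amounts of compound), compound 1 gives the lowest number of the three, compound 3 the nearest and compound 2 the furthest. Compound 4 `COC(=O)C1=C(C)N=C(C)/C(=C(\O)OC)C1c1cc(C)ccc1C` has not yet been measured in this assay. It differs from compound 1 in one place: 2,5-dimethylphenyl in place of 2-chlorophenyl on a saturated ring carbon. Among the compounds with values here, the only step within the set that touches the aryl group, a 14-fold higher number from compound 1 to compound 3 (1.14 log units; beyond the scatter), is large. Compound 2, which carries a trimethoxyphenyl, gives a number far above both. A further substituent on this aryl therefore appears to raise the number, so a moderate rise is expected here, a 6.8-fold higher number from compound 1 to compound 4 (0.84 log units; beyond the scatter). Compound 4 is estimated at 15 nM, between 3 nM and 80 nM.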

Compound 4, half-maximal effective concentration: 100 nM
Compound 4: the middle estimate sits 6.7-fold (0.82 log units) below what was measured; measured number outside the range, above it.
By their numbers in this assay, from the lowest: compound 1; then compound 3; then compound 4; then compound 2.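

In this assay the aryl group on the saturated ring carbon also responds to a change with no chlorine in the incoming group and no new hydrogen-bond donor or acceptor, with a 46-fold higher number from compound 1 to compound 4 (1.66 log units; beyond the scatter) as the result. Within the data shown here, compound 3 keeps its chlorine, so this is the first step showing what replacing 2-chlorophenyl costs. No evidence on the cause of this step is available.

The step combines loss of chlorine with gain of two methyl groups, so their separate shares remain unresolved. A 2-methylphenyl or 2-bromophenyl group at this carbon would separate them.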